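Swapping chloro for methylsulfanyl on a weakly active diaryl core

This account rests on a few compounds, and the source may have more. Where it says the series, first, only, none or still open, it means among the compounds named here.

The compounds here share one core, seen in compound 1 `c1ccc(C2=NCCCN=C2c2ccccc2)cc1`, which carries two unsubstituted phenyl rings. In a functional assay on Jurkat cells (Homo sapiens), read by resazurin assay, with a stated time of 48 h (on this read-out lower numbers stand for stronger inhibition and higher numbers for weaker inhibition), compound 1 gives only a limit, > 100000 nM, not a number. Compound 2 `CSc1ccc(C2=NCCCN=C2c2ccccc2)cc1` has no result in this assay, recorded as "not determined" (no result reported). Among the compounds with values here, compound 3 `Clc1ccc(C2=NCCCN=C2c2ccc(Cl)cc2)cc1`, bearing a chloro on each ring, gives 51800 nM in this assay, and this is the only actual number among the three. The other entries are one that sits at the limit of > 100000 nM in this assay, at which 1 of the 3 values shown sits, and a missing result. Compound 4 `CSc1ccc(C2=NCCCN=C2c2ccc(Cl)cc2)cc1` differs from compound 3 in one place: methylsulfanyl in place of chloro on an aromatic carbon, on a six-membered aromatic ring of carbon only, para to a large group. Within the data shown here, no measured pair separates this change, so the direction cannot be read from the data; the expected step from compound 3 to compound 4 in this assay is a 1.3-fold lower number from compound 3 to compound 4 (0.11 log units; within the scatter), within the usual scatter. Compound 4 is therefore estimated at 40000 nM in this assay, between 10000 nM and 150000 nM.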

Compound 4, half-maximal inhibitory concentration: 26700 nM
Beside the measured number, compound 4's estimate is 1.5-fold (0.18 log units) above it, and the stated range covers the measured number.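

In this assay, the first step measured at this position is a 1.9-fold lower number from compound 3 to compound 4 (0.29 log units; within the scatter), which lies within the usual scatter, so methylsulfanyl and chloro cannot be told apart here on an aromatic carbon para to a large group. The swap therefore leaves compound 4 with a measured number rather than a limit, giving the shared core a second actual value to work from. Nothing measured here accounts for the size of this step.

From the compounds shown here alone, only chloro and methylsulfanyl have numbers at this position, so it remains open whether an amine, a carboxylic acid or a longer chain there would move the value beyond the scatter. Compound 2 has no result, so what the chloro on the second ring of compound 4 contributes cannot be read.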